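The source may hold more compounds than are shown below. What is called first, only, known or untested is meant among the compounds shown, and "the series" means these compounds.

Compound 3 `COC(=O)/C=C/c1cccc(N(Cc2ccc(C(C)(C)C)cc2)C(=O)C2CCCCC2)c1` stands at the limit of an assay on isolated protein with Bile acid receptor (Homo sapiens) as the target (a higher number here means that more compound is needed for the effect, a lower number that less compound is needed), where it gives only > 1000 nM rather than a number. Compound 2 `COC(=O)/C=C/c1cccc(N(Cc2ccccc2)C(=O)C2CCCCC2)c1` likewise gives only the limit > 1000 nM in this assay. Compound 1 `COC(=O)/C=C/c1cccc(N(Cc2ccc(-c3cccc(C)c3)cc2)C(=O)C2CCCCC2)c1` gives 109 nM in this assay. The steps bearing on the change are an at least 9.1-fold higher number from compound 1 to compound 3 (0.96 log units; beyond the scatter) and an at least 9.1-fold higher number from compound 1 to compound 2 (0.96 log units; beyond the scatter), while a step that the two limits leave unreadable from compound 2 to compound 3 cannot be sized because both values sit at the limit of > 1000 nM in this assay, at which 2 of the 3 values shown sit. Compound 4 `COC(=O)/C=C/c1cccc(N(Cc2ccc(/C=C/C(=O)N(C)C)cc2)C(=O)C2CCCCC2)c1` carries 2-(dimethylcarbamoyl)ethenyl in place of tert-butyl on an aromatic carbon. Since the extended 3-methylphenyl of compound 1 reaches 109 nM where the tert-butyl of compound 3 does not, the longer 2-(dimethylcarbamoyl)ethenyl is expected to move the number in this assay downward, by the estimated step of an at least 1.6-fold lower number from compound 3 to compound 4 (0.22 log units; that floor lies within the scatter). Compound 4 is therefore estimated at 600 nM, within 120 nM to 3000 nM.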

Compound 4, half-maximal effective concentration: > 1000 nM
Compound 4 was reported as a limit (the forecaster's own chance of this, stated with the estimate: 40%); middle value at least 1.6-fold (0.22 log units) away from the limit.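

In this assay, more heavy atoms at this position do not by themselves give a measurable value: 2-(dimethylcarbamoyl)ethenyl, a chain with no ring, in place of 3-methylphenyl gives an at least 9.1-fold higher number from compound 1 to compound 4 (0.96 log units; beyond the scatter). Compound 4 gives only a limit, not a number: the limit of > 1000 nM in this assay, at which 3 of the 4 values shown sit. The steps to compound 4 from compound 2 and compound 3 cannot be read.

As far as these compounds go, what remains open is whether a plain phenyl would keep the value of compound 1, which would separate the ring from its methyl. From the compounds shown here alone, it is also open whether a carboxylic acid in place of the dimethylcarbamoyl end would change the limit.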